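A few compounds are considered here, and "the series" means these few. Any claim that something is new, unique, unknown or untested is made for them only; others in the source may bear on it.

In a functional assay on MIA PaCa-2 cells (Homo sapiens) for inhibition, read by MTT assay, with a stated time of 7 days (a higher number here means a weaker inhibitor, a lower number a stronger inhibitor), compound 1 `CCN(CC)S(=O)(=O)c1ccc(S(=O)(=O)N2CCC[C@@H](C(=O)N3CCC(O)CC3)C2)cc1` gives 870 nM, the second highest of the three numbers shown. Compound 3 `CN(C)S(=O)(=O)c1ccc(S(=O)(=O)N2CCC[C@@H](C(=O)N3CCC(F)(F)CC3)C2)cc1` gives 118 nM, and compound 2 `CCN(CC)S(=O)(=O)c1ccc(S(=O)(=O)N2CCC[C@@H](C(=O)NC3CCOCC3)C2)cc1` gives 3770 nM. Compound 4 `CCN(CC)S(=O)(=O)c1ccc(S(=O)(=O)N2CCC[C@@H](C(=O)N[C@@H]3CCOC3)C2)cc1` differs from compound 1 by (oxolan-3-yl)amino in place of 4-hydroxypiperidin-1-yl on a carbonyl carbon. For the measured compounds named here, the one measured step that bears on this is the exchange of the same 4-hydroxypiperidin-1-yl for (oxan-4-yl)amino on the same carbonyl carbon, which gave a 4.3-fold higher number from compound 1 to compound 2 (0.64 log units; beyond the scatter). A higher number in this assay of roughly that size is therefore expected for compound 4, as a 3.4-fold higher number from compound 1 to compound 4 (0.54 log units; beyond the scatter). Compound 4 is estimated at 3000 nM in this assay, with a range of 1200 nM to 8000 nM.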

Compound 4, half-maximal inhibitory concentration: 750 nM
Compound 4: the middle estimate sits 4.0-fold (0.60 log units) above what was measured, and the stated range ends above it.
By their numbers in this assay, from the lowest: compound 3; then compounds 4 and 1 (each within the scatter of the next); then compound 2.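

On this carbonyl carbon, (oxolan-3-yl)amino in place of 4-hydroxypiperidin-1-yl gives a 1.2-fold lower number from compound 1 to compound 4 (0.06 log units; within the scatter) so leaving 4-hydroxypiperidin-1-yl does not in itself bring the loss seen with (oxan-4-yl)amino. The group on the amide-type nitrogen decides the outcome here: oxolan-3-yl in place of oxan-4-yl gives a 5.0-fold lower number from compound 2 to compound 4 (0.70 log units; beyond the scatter) and this position separates these two ring ethers. No evidence is available on the origin of these steps.

Still open, on these data alone, is how the other stereoisomer of the oxolan-3-yl group would read. Equally open, as far as these compounds go, is whether an open-chain group such as 2-methoxyethylamino would follow compound 4 or compound 2.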